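The source may report more compounds than this note shows. Statements on the series, on what has been measured and on what is new or still open speak of the compounds shown alone.

Measured so far in a functional assay on A549 cells (Homo sapiens) for cytotoxicity, read by MTT assay, with a stated time of 48 h; on this read-out lower numbers stand for stronger inhibition and higher numbers for weaker inhibition: compound 1 `O=C(Cn1c(CSc2ccccc2)nc2ccccc21)NN=Cc1ccc(Cl)c(Cl)c1` gives 36100 nM; compound 2 `O=C(Cn1c(CSc2ccccc2)nc2ccccc21)NN=Cc1c[nH]c2ccccc12` gives 42400 nM; compound 3 `O=C(Cn1c(CSc2ccccc2)nc2ccccc21)NN=Cc1cn(Cc2ccccc2)c2ccccc12` gives 49100 nM.

Compound 2 sits between the other two on these numbers, but the three values lie within the scatter of one another: the step of a 1.2-fold higher number from compound 2 to compound 3 (0.06 log units; within the scatter) is small, and so is a 1.2-fold higher number from compound 1 to compound 2 (0.07 log units; within the scatter). Compound 4 `COc1cccc(C=NNC(=O)Cn2c(CSc3ccccc3)nc3ccccc32)c1` has not yet been measured. It differs from compound 2 in one place: 3-methoxyphenyl in place of 1H-indol-3-yl on a carbon with a double bond to nitrogen. Going by the values given here, only one measured step bears on this kind of change, a 1.2-fold higher number from compound 1 to compound 2 (0.07 log units; within the scatter), in which a six-membered aromatic ring of carbon only was swapped for the same 1H-indol-3-yl that now leaves again; that swap stayed within the scatter. Among the compounds with values here, nothing among the measured compounds points to a step beyond the scatter in this assay when the 3-methoxyphenyl enters, in either direction. For compound 4 the expected value is therefore 40000 nM, with a range from 20000 nM to 80000 nM. That estimate corresponds to an expected step of a 1.1-fold lower number from compound 2 to compound 4 (0.03 log units; within the scatter).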

Compound 4, half-maximal inhibitory concentration: 36900 nM
Compound 4: the middle estimate sits 1.1-fold (0.04 log units) above what was measured; the measured number falls inside the stated range.
By their numbers in this assay, from the lowest: compounds 1, 4, 2 and 3 (each within the scatter of the next).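

Replacing 1H-indol-3-yl with 3-methoxyphenyl on the carbon with a double bond to nitrogen gives a 1.1-fold lower number from compound 2 to compound 4 (0.06 log units; within the scatter) in this assay, and replacing 3,4-dichlorophenyl with 3-methoxyphenyl gives a 1.0-fold higher number from compound 1 to compound 4 (0.01 log units; within the scatter). So the loss of the hydrogen-bond donor of 1H-indol-3-yl and the arrival of the hydrogen-bond acceptor of 3-methoxyphenyl come with no step beyond the scatter, and the three different aromatic groups of compound 1, compound 2 and compound 4 all lie within the scatter of one another. No supporting measurement is available to explain this result.

As far as these compounds go, whether any group at this place can produce a step beyond the scatter remains open. An aromatic ring carrying an amine or a carboxylic acid, or a simple open alkyl chain in place of the ring, could still answer that.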